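The source may report more compounds than this note shows. Statements on the series, on what has been measured and on what is new or still open speak of the compounds shown alone.

Of the compounds shown here, two have been measured in a functional assay on COLO 205 cells (Homo sapiens) for inhibition, read by sulforhodamine B assay, tested at 100 uM; on this read-out higher numbers stand for more inhibition of growth at the one concentration tested and lower numbers for less inhibition of growth. Compound 1 `COc1cc(C2CC(c3ccc([N+](=O)[O-])cc3)=NN2C(C)=O)ccc1OCc1cn(Cc2ccc([N+](=O)[O-])cc2)nn1` gives 85% in this assay, and compound 2 `COc1ccc(C2=NN(C(C)=O)C(c3ccc(OCc4cn(Cc5ccc([N+](=O)[O-])cc5)nn4)c(OC)c3)C2)cc1` gives 75%. The one step between them, a number 10 percentage points lower from compound 1 to compound 2 (within the scatter), is too small to count as a real difference, so although compound 2 holds the lower of the two numbers shown, it cannot be told apart from compound 1 on this evidence.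

Compound 3 `COc1cc(C2CC(c3ccc(Cl)cc3)=NN2C(C)=O)ccc1OCc1cn(Cc2ccc([N+](=O)[O-])cc2)nn1` is the next compound in line. The change from compound 2 to compound 3 is chloro in place of methoxy on an aromatic carbon. For the measured compounds named here, the only measured step that bears on it is the one at the same position, from compound 1 to compound 2, where a nitro group was exchanged for a methoxy group and the result stayed within the scatter. A second exchange at that same position, this time to chloro, is therefore expected to move the read-out by no more than the scatter in either direction. Compound 3 is expected to reach 78% in this assay, within a range from 60% to 92%, which means an expected step of a number 3 percentage points higher from compound 2 to compound 3 (within the scatter).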

Compound 3, percent growth inhibition at one concentration: 10%
Beside the measured number, compound 3's estimate is 68 percentage points above it, and the stated range ends above it.
By their numbers in this assay, from the lowest: compound 3; then compounds 2 and 1 (each within the scatter of the next).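

In this assay, the place held by the 4-methoxyphenyl group in compound 2 turns out to be far from indifferent: chloro in place of methoxy gives a number 65 percentage points lower from compound 2 to compound 3 (beyond the scatter), and chloro in place of nitro gives a number 75 percentage points lower from compound 1 to compound 3 (beyond the scatter). The earlier pair alone made this position look tolerant of change, since nitro and methoxy could not be told apart, whereas the three compounds together show that the choice of group here can decide whether growth is strongly inhibited at the one concentration tested, with chloro standing clearly apart from the other two. No accompanying measurement offers an explanation for this large drop, so it stands as an observation only.

Going by these compounds, with only nitro, methoxy and chloro at this position, it remains open whether the low number belongs to chloro alone or would also appear with other groups, such as fluoro, bromo, methyl or an amine. On these data alone, it also remains open whether the same gap would hold at concentrations other than the single one used here.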